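A few compounds are considered here, and "the series" means these few. Any claim that something is new, unique, unknown or untested is made for them only; others in the source may bear on it.

Compound 1 `O=C(/C=C/c1ccccc1F)NCCO`: 35.3 mg/kg
Compound 2 `O=C(/C=C/c1ccccc1Cl)NCCO`: 59 mg/kg
Compound 3 `O=C(/C=C/c1ccccc1Br)NCCO`: not yet measured

In a functional assay on the whole organism (strain Kunming) with Mus musculus as the target, in the maximal electroshock model (a lower number here means that less compound is needed, a higher number that more compound is needed for the effect), compound 2 gives 59 mg/kg and compound 1 gives 35.3 mg/kg. These two values cannot be told apart, since repeat measurements of this kind vary about as much. Compound 3 keeps the core of compound 2 and makes a single change: bromo in place of chloro on an aromatic carbon.

Among the compounds with values here, only one measured step bears on this change, the swap of chloro in place of fluoro on an aromatic carbon: a 1.7-fold higher number from compound 1 to compound 2 (0.22 log units; within the scatter). That single step gives no firm direction, so no change beyond the scatter is expected in this assay. The expected step is a 1.0-fold higher number from compound 2 to compound 3 (0.01 log units; within the scatter). For compound 3 the estimated value is 60 mg/kg, with an expected range of 30 mg/kg to 120 mg/kg.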

Compound 3, dose for half-maximal effect: 68.2 mg/kg
Compound 3: middle estimate off by 1.1-fold (0.06 log units), on the low side, and the stated range covers the measured number.
By their numbers in this assay, from the lowest: compounds 1, 2 and 3 (each within the scatter of the next).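

In this assay, bromo in place of chloro gives a 1.2-fold higher number from compound 2 to compound 3 (0.06 log units; within the scatter) and bromo in place of fluoro gives a 1.9-fold higher number from compound 1 to compound 3 (0.29 log units; within the scatter) on the same aromatic carbon. With bromo added, fluoro, chloro and bromo have all been compared at this position, ortho to a group of 8 heavy atoms, and every step among the three compounds lies within the scatter, so exchanging one of these halogens for another has no measurable effect in this assay. No supporting measurement is available to explain this result.

The compounds shown leave open whether a group that is not a halogen, such as an amine or a methoxy group, would change the number at this position. They also leave open whether a longer chain on the amide nitrogen would do so.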